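The source may hold more compounds than are shown below. What is called first, only, known or untested is meant among the compounds shown, and "the series" means these compounds.

Working notes on the series. In a functional assay on KB cells (Homo sapiens) for inhibition, read by colony formation (on this read-out lower numbers stand for an effect already at smaller amounts and higher numbers for an effect only at larger amounts of compound), compound 2 `CCOC(=O)Nc1cc2ncc(CN(C)c3ccccc3)nc2c(N)n1` gives 6.7 uM. Compound 1 `CCOC(=O)Nc1cc2c(c(NC(=O)OCC)n1)N=C(C)CN2` gives 91 uM in this assay. Of the two numbers recorded, compound 2 holds the lower, and its gap to compound 1 lies beyond the scatter. Compound 3 `CN(Cc1cnc2cc(N)nc(N)c2n1)c1ccccc1` is recorded in this assay only as a limit, > 100 uM; this is the limit of > 100 uM in this assay, at which 1 of the 3 values shown sits. Within the data shown here, the single step between measured compounds that differ in one place is an at least 14-fold higher number from compound 2 to compound 3 (1.17 log units; beyond the scatter).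

Compound 4 `CCOC(=O)Nc1cc2ncc(CN(C)c3ccc(C(=O)OC)cc3)nc2c(N)n1` differs from compound 2 by methoxycarbonyl in place of hydrogen on an aromatic carbon. Among the measured compounds shown here, the measured step concerns the ethoxycarbonyl on the ring nitrogen, which compound 4 keeps; no measured pair varies the phenyl ring, so nothing recorded bears on this change. The expectation is therefore a step of a 1.0-fold higher number from compound 2 to compound 4 (0.02 log units; within the scatter), not beyond the scatter. Compound 4 is estimated at 7 uM in this assay, with a range from 2 uM to 25 uM.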

Compound 4, concentration for half-maximal effect: 19 uM
Estimate against measurement, compound 4: 2.7-fold (0.43 log units) below; the measured number falls inside the stated range.
By their numbers in this assay, from the lowest: compound 2; then compound 4; then compound 1. At a limit, above all of these: compound 3.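

The phenyl ring now proves sensitive to substitution, which the earlier step, confined to the ethoxycarbonyl on the ring nitrogen, could not show. In this assay, 4-(methoxycarbonyl)phenyl in place of phenyl gives a 2.8-fold higher number from compound 2 to compound 4 (0.45 log units; beyond the scatter), so an aromatic carbon para to a large group is a place where a change registers, though only modestly. Compound 4 still gives a measured number, 19 uM, and nothing recorded gives a cause for the step.

The compounds shown leave open whether this step belongs to methoxycarbonyl itself or would follow any group at this carbon, such as a carboxylic acid, an amine or a fluorine atom. They also leave open how the same change would read with the ethoxycarbonyl on the ring nitrogen replaced by a longer chain.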